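This account rests on a few compounds, and the source may have more. Where it says the series, first, only, none or still open, it means among the compounds named here.

Measured compounds:
compound 1 `Sc1nnc(Sc2nnc(-c3ccccc3)n2-c2ccccc2)n1-c1ccccc1`: 28300 nM
compound 2 `Sc1nnc(CSc2nnc(-c3ccccc3)n2-c2ccccc2)n1-c1ccc(Cl)cc1`: 36600 nM
compound 3 `Sc1nnc(Sc2nnc(-c3ccccc3)n2-c2ccccc2)n1-c1ccc(Cl)cc1`: 38400 nM

In a functional assay on HT-29 cells (Homo sapiens) for inhibition, read by MTT assay, with a stated time of 48 h (on this read-out lower numbers stand for stronger inhibition and higher numbers for weaker inhibition), compound 1 gives 28300 nM, compound 2 gives 36600 nM, and compound 3 gives 38400 nM. All three numbers lie within the scatter of each other, so no ordering among them can be read from these data. Compound 3 and compound 1 differ only by hydrogen in place of chloro on an aromatic carbon, and this change produced a 1.4-fold lower number from compound 3 to compound 1 (0.13 log units; within the scatter). The cores of compound 2 and compound 3 differ in a way that is not broken down here.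

Compound 4 `Sc1nnc(CSc2nnc(-c3ccccc3)n2-c2ccccc2)n1-c1ccccc1` has not yet been measured in this assay . It differs from compound 2 by hydrogen in place of chloro on an aromatic carbon, the same kind of change that separates compound 3 from compound 1; the place lines of the two changes read alike word for word. Compound 4 is therefore expected to sit close to compound 2, with a step of about a 1.4-fold lower number from compound 2 to compound 4 (0.13 log units; within the scatter), because the earlier step of a 1.4-fold lower number from compound 3 to compound 1 (0.13 log units; within the scatter) stayed within the scatter. Compound 4 is estimated at 27000 nM, with a range from 13000 nM to 55000 nM.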

Compound 4, half-maximal inhibitory concentration: 5490 nM
For compound 4 the middle estimate is 4.9-fold (0.69 log units) above the measured one; the whole stated range lies above it.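

In this assay, the change from 4-chlorophenyl to phenyl on the core of compound 2 gives a 6.7-fold lower number from compound 2 to compound 4 (0.82 log units; beyond the scatter). The same change on the core of compound 3 gave a much smaller step, so in this series its size cannot simply be carried from one core to the other: the same change on two cores in this assay, a 1.4-fold lower number (0.13 log units; within the scatter) from compound 3 to compound 1 and a 6.7-fold lower number (0.82 log units; beyond the scatter) from compound 2 to compound 4, 4.9-fold (0.69 log units) apart, beyond the scatter of two such steps This shows that the size of the step went with the core in these two pairs, but two pairs do not show why they part or what the change would do on any further core.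

The compounds shown carry only hydrogen or chloro at this place, so it remains open whether a fluoro group, a methoxy group or an amine there would follow the larger step or the smaller one. Also open, on these data alone, is whether the larger step would hold with a longer chain at the point where the core of compound 2 differs from the core of compound 3.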